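The source may hold more compounds than are shown below. What is called first, only, known or untested is meant among the compounds shown, and "the series" means these compounds.

Going by the values given here, compound 1 `Cc1cccc(Cl)c1NC(=O)Nc1ccncc1` gives 30 mg/kg in a functional assay on the whole organism with Mus musculus as the target, in the maximal electroshock model, with a stated time of 30 min (a lower number here means that less compound is needed, a higher number that more compound is needed for the effect), the lowest of the two numbers known here; its nearest neighbour is compound 2 `Cc1cc(C)c(NC(=O)Nc2ccncc2)c(Cl)c1`, which gives 100 mg/kg, a step of a 3.3-fold higher number from compound 1 to compound 2 (0.52 log units; beyond the scatter). Compound 3 `Cc1cc(NC(=O)Nc2c(C)cccc2Cl)ccn1`, not yet measured, differs from compound 1 by methyl in place of hydrogen on an aromatic carbon, the methyl here sitting on the six-membered aromatic ring with 1 nitrogen rather than on the other ring. Among the compounds with values here, the one step that bears on it, a 3.3-fold higher number from compound 1 to compound 2 (0.52 log units; beyond the scatter), is the same kind of change at a different place, so a modest rise or none beyond the scatter is expected. Compound 3 is therefore estimated at 50 mg/kg, between 20 mg/kg and 150 mg/kg, a step of a 1.7-fold higher number from compound 1 to compound 3 (0.22 log units; within the scatter).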

Compound 3, minimum effective dose: 30 mg/kg
Beside the measured number, compound 3's estimate is 1.7-fold (0.22 log units) above it, within the range that was stated.
By their numbers in this assay, from the lowest: compounds 1 and 3 (each within the scatter of the next); then compound 2.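

In this assay, methyl in place of hydrogen on the six-membered aromatic ring with 1 nitrogen, next to the ring nitrogen, gives no change at the digits printed from compound 1 to compound 3 (within the scatter). The same replacement on the other ring gave a 3.3-fold higher number from compound 1 to compound 2 (0.52 log units; beyond the scatter), so across these two steps the outcome depends on where the methyl sits. No measurement at hand accounts for this difference between the two places. Still open, going by these compounds, is whether this position would tolerate anything other than methyl, such as an ethyl, a methoxy or an amine.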